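Cinnamamide versus benzamide pair with para-halogen swap

The source may report more compounds than this note shows. Statements on the series, on what has been measured and on what is new or still open speak of the compounds shown alone.

Measured so far:
Compound 1, `Nc1ccccc1NC(=O)/C=C/c1ccc(CSc2ccc(Cl)cc2)cc1`, gives 59.6% in a functional assay on A549 cells (Homo sapiens) for inhibition, read by CCK-8 assay, with a stated time of 72 h, tested at 8 uM; a higher number here means more inhibition of growth at the concentration tested, a lower number less inhibition of growth.
Compound 2, `Nc1ccccc1NC(=O)/C=C/c1ccc(CSc2ccc(F)cc2)cc1`, gives 59.1% in this assay.
Compound 3, `Nc1ccccc1NC(=O)c1ccc(CSc2ccc(F)cc2)cc1`, gives 44.5% in this assay.

Compound 4, `Nc1ccccc1NC(=O)c1ccc(CSc2ccc(Cl)cc2)cc1`, is not yet measured in this assay.

Within the pair sharing the core of compound 2, the change chloro in place of fluoro on an aromatic carbon gave a number 0.5 percentage points higher from compound 2 to compound 1 (within the scatter); the two values sit within the scatter of each other. Compound 3 carries a different core; how the two cores differ is not broken down here. Its value stands lowest of the three, and both gaps to compound 1 and to compound 2 lie beyond the scatter.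

Compound 4 is reached from compound 3 by chloro in place of fluoro on an aromatic carbon, the same change as between compound 2 and compound 1, on the same kind of place. Among the compounds with values here, on the core of compound 2 that change was flat; on the core of compound 3 the step is expected to be flat as well, a number 0.5 percentage points higher from compound 3 to compound 4 (within the scatter), resting on the single comparison a number 0.5 percentage points higher from compound 2 to compound 1 (within the scatter). Compound 4 is therefore estimated at 45% in this assay, between 35% and 56%.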

Compound 4, percent growth inhibition at one concentration: 50.4%
Compound 4: middle estimate off by 5.4 percentage points, on the low side; measured number inside the range.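

In this assay, chloro in place of fluoro on the core of compound 3 gives a number 5.9 percentage points higher from compound 3 to compound 4 (within the scatter), so this halogen swap leaves no reading that stands clear of the scatter on this core. On the two cores shown, the change carries over without a difference that can be told apart: the same change on two cores in this assay, a number 0.5 percentage points higher (within the scatter) from compound 2 to compound 1 and a number 5.9 percentage points higher (within the scatter) from compound 3 to compound 4, 5.4 percentage points apart, within the scatter of two such steps. This supports treating the swap as flat on these two cores only; it does not show that the two steps are identical, that a small real difference is absent, or that the same would hold on a third core or at another concentration.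

The compounds shown leave open how other groups would read on that aromatic carbon, such as bromo, methoxy, trifluoromethyl or a nitrile. Also open, from the compounds shown here alone, is whether the flat step would survive a change at the linking sulfur, for instance an oxygen or a methylene group in its place.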